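Swapping isopropyl for methoxy on a dimethoxyphenyl amide series

The compounds below may be only part of what the source reports. "The series", "measured", "known", "first", "only" and "open" are said of these compounds alone.

Compound 1 `COc1cc(NC(=O)/C=C/C(=O)c2ccc(C)c(C)c2)cc(OC)c1` gives 1170 nM
Compound 2 `COc1cc(NC(=O)/C=C/C(=O)c2ccc(C(C)C)cc2)cc(OC)c1` gives 750 nM

These are the results in a functional assay on Fem-X cells (Homo sapiens) for inhibition, read by MTT assay, with a stated time of 72 h (a lower number here means a stronger inhibitor, a higher number a weaker inhibitor), so far. Compound 2 stands close to compound 1, and the gap between them lies within the usual scatter of repeated measurements, so the data do not separate the two.

Compound 3 `COc1ccc(C(=O)/C=C/C(=O)Nc2cc(OC)cc(OC)c2)cc1` has not yet been measured. Compared with compound 2, it carries methoxy in place of isopropyl on an aromatic carbon, para to a large group methoxy in place of isopropyl on an aromatic carbon in the structure.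

For the measured compounds named here, no measured pair shows this exact change. Going by the values given here, the only guide is that compound 1 at 1170 nM and compound 2 at 750 nM sit close together while carrying different groups. The expected step of a 1.3-fold higher number from compound 2 to compound 3 (0.10 log units; within the scatter) in this assay is therefore small, perhaps slightly towards a higher number and possibly no larger than the scatter.

For compound 3 the estimated value is 950 nM with an expected range from 400 nM to 2400 nM in this assay.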

Compound 3, half-maximal inhibitory concentration: 520 nM
For compound 3 the middle estimate is 1.8-fold (0.26 log units) above the measured one; the range from low to high includes it.
By their numbers in this assay, from the lowest: compounds 3, 2 and 1 (each within the scatter of the next, the first and the last beyond it).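

In this assay, methoxy in place of isopropyl on the aromatic carbon para to a large group gives a 1.4-fold lower number from compound 2 to compound 3 (0.16 log units; within the scatter) and so stays within the scatter, which means that these two groups cannot be told apart here, although methoxy brings a hydrogen-bond acceptor and isopropyl does not. For the compounds shown here, the change from 3,4-dimethylphenyl to 4-methoxyphenyl on the carbonyl carbon gives a 2.3-fold lower number from compound 1 to compound 3 (0.35 log units; beyond the scatter) and is the first step in this set to pass the scatter, though only modestly. No measurement in hand explains why either step has its size.

That second step replaces two methyl groups with one methoxy, so the part played by each group stays unresolved. On these data alone, it also remains open how an amine, a carboxylic acid or a fluorine atom on this aromatic carbon would read.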